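A Chloro Substituent on the Dimethoxyphenyl Analogue

The source may report more compounds than this note shows. Statements on the series, on what has been measured and on what is new or still open speak of the compounds shown alone.

In a functional assay on U-87MG ATCC cells for antiproliferative activity against U-87 MG (Homo sapiens), read by MTT assay, with a stated time of 48 h, tested at 5 uM (a lower number here means a stronger effect, a higher number a weaker effect of the compound at the concentration tested), compound 2 `Cc1nc(-c2ccccc2)sc1C(=O)CSc1nc(-c2ccccc2)c(C#N)c(=O)[nH]1` gives 92.1%. Compound 1 `Cc1nc(-c2ccc(Cl)cc2)sc1C(=O)CSc1nc(-c2ccccc2)c(C#N)c(=O)[nH]1` carries chloro in place of hydrogen on an aromatic carbon relative to compound 2, and in this assay compound 1 gives 88.9%; that step is a number 3.2 percentage points lower from compound 2 to compound 1 (within the scatter). Compound 3 `COc1ccc(-c2nc(SCC(=O)c3sc(-c4ccccc4)nc3C)[nH]c(=O)c2C#N)cc1OC` differs from compound 2 by 3,4-dimethoxyphenyl in place of phenyl on an aromatic carbon, and in this assay compound 3 gives 80.8%, a step of a number 11.3 percentage points lower from compound 2 to compound 3 (beyond the scatter). Compound 4 `COc1ccc(-c2nc(SCC(=O)c3sc(-c4ccc(Cl)cc4)nc3C)[nH]c(=O)c2C#N)cc1OC` has not yet been measured. It differs from compound 3 by chloro in place of hydrogen on an aromatic carbon, the same change as that from compound 2 to compound 1, here made on the core of compound 3 rather than on the core of compound 2. The earlier instance of this change gave a number 3.2 percentage points lower from compound 2 to compound 1 (within the scatter), a small step. For compound 4 the expected step is therefore a number 2.8 percentage points lower from compound 3 to compound 4 (within the scatter), again small. This expectation rests on that single earlier step and on the value of compound 3, 80.8%, as its starting point. Compound 4 is thus estimated at 78%, expected to fall between 68% and 88%.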

Compound 4, a percentage reported as activity, at one concentration (the size of the read-out at that concentration, not a potency): 93.4%
The estimate for compound 4 lay 15.4 percentage points below the measured number; measured number outside the range, above it.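

In this assay the chloro change did not carry over from one core to the other: on the core of compound 3 it gave a number 12.6 percentage points higher from compound 3 to compound 4 (beyond the scatter), opposite in direction to its earlier step, and the two steps differ: the same change on two cores in this assay, a number 3.2 percentage points lower (within the scatter) from compound 2 to compound 1 and a number 12.6 percentage points higher (beyond the scatter) from compound 3 to compound 4, 15.8 percentage points apart, beyond the scatter of two such steps The same four compounds read the other way show that 3,4-dimethoxyphenyl in place of phenyl, which gives a number 4.5 percentage points higher from compound 1 to compound 4 (within the scatter) on the chlorinated core, also did not repeat its earlier step: the same change on two cores in this assay, a number 11.3 percentage points lower (beyond the scatter) from compound 2 to compound 3 and a number 4.5 percentage points higher (within the scatter) from compound 1 to compound 4, 15.8 percentage points apart, beyond the scatter of two such steps In this series, then, the two changes do not add up, and a step seen on one core did not hold on the other, but this single square of compounds does not show what lies behind the difference or how the change would behave on any further core.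

The compounds shown leave open whether a fluoro, a methyl or an amine in place of the chloro would depend on the core in the same way. From the compounds shown here alone, it also stays open whether a single methoxy group on the other phenyl would behave as 3,4-dimethoxyphenyl does.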